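The source may report more compounds than this note shows. Statements on the series, on what has been measured and on what is new or still open speak of the compounds shown alone.

Measured compounds in a functional assay on K562 cells (Homo sapiens) for antiproliferative activity; a lower number here means a stronger inhibitor, a higher number a weaker inhibitor:
- compound 1, `Cc1cn(-c2cc(NC(=O)c3ccc(C)c(Nc4nc(-c5cccnc5)cs4)c3)cc(C(F)(F)F)c2)cn1`: 1830 nM
- compound 2, `Cc1cn(-c2cc(NC(=O)c3ccc(C)c(Nc4nc(-c5cccnc5)cs4)c3)cc(C(C)C)c2)cn1`: 2910 nM

Compound 2 stands with one neighbour only. Its number in this assay and that of compound 1 lie within the scatter of each other, separated by a 1.6-fold higher number from compound 1 to compound 2 (0.20 log units; within the scatter), a change that swapped isopropyl for trifluoromethyl on an aromatic carbon and left the read-out essentially unmoved.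

Compound 3, `Cc1cn(-c2cc(NC(=O)c3ccc(C)c(Nc4nc(-c5cccnc5)cs4)c3)cc(C(C)(C)C)c2)cn1`, has not yet been measured. It differs from compound 2 by methyl in place of hydrogen on a saturated chain carbon bound to an aromatic carbon and two saturated chain carbons; cut one bond further out, the same difference reads isopropyl to tert-butyl. Within the data shown here, no measured step shows this exact change. Among the measured compounds shown here, the one step that bears on it, a 1.6-fold higher number from compound 1 to compound 2 (0.20 log units; within the scatter), concerns the same position and was within the scatter; it shows that a change of group at this aromatic carbon has so far not moved the read-out beyond the scatter.

Compound 3 is therefore expected to sit close to compound 2, with an estimated step of a 1.2-fold higher number from compound 2 to compound 3 (0.08 log units; within the scatter) in this assay. Compound 3 is estimated at 3500 nM, with a range from 1500 nM to 8500 nM.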

Compound 3, half-maximal inhibitory concentration: 640 nM
The estimate for compound 3 lay 5.5-fold (0.74 log units) above the measured number, and the stated range ends above it.
By their numbers in this assay, from the lowest: compound 3; then compounds 1 and 2 (each within the scatter of the next).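

In this assay this aromatic carbon no longer looks indifferent to the group it carries: methyl in place of hydrogen on the saturated chain carbon, which turns isopropyl into tert-butyl, gives a 4.5-fold lower number from compound 2 to compound 3 (0.66 log units; beyond the scatter) and tert-butyl in place of trifluoromethyl gives a 2.9-fold lower number from compound 1 to compound 3 (0.46 log units; beyond the scatter), both modest but beyond the scatter. The earlier pair lay within the scatter of each other and so hid this, and a single added methyl now sets compound 3 apart from both compound 1 and compound 2, with the lowest number of the three. Nothing available accounts for why this one methyl separates the compounds when the swap of isopropyl for trifluoromethyl did not.

The compounds shown carry only three groups at this place, so it stays open whether a cyclohexyl ring, a longer branched chain or an amine there would lower the number further or raise it again. From the compounds shown here alone, it also stays open whether the step to tert-butyl holds when another part of the shared core is changed.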